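This account rests on a few compounds, and the source may have more. Where it says the series, first, only, none or still open, it means among the compounds named here.

Measured compounds in a functional assay on SW480 cells (Homo sapiens) for cytotoxicity, read by MTT assay, with a stated time of 24 h; a higher number here means a weaker inhibitor, a lower number a stronger inhibitor:

Compound 1, `C=CC1=C(C(=O)NCCC)C(c2ccc(F)cc2)OC1`, gives > 100000 nM, a limit of the assay and not a number.
Compound 2, `C=CC1=C(C(=O)NCCC)C(c2ccc(Cl)c(Cl)c2)OC1`, gives > 100000 nM, again a limit of the assay.
Compound 3, `C=CC1=C(C(=O)NCC(C)C)C(c2ccc(Cl)c(Cl)c2)OC1`, gives > 100000 nM, also a limit of the assay.

Where compound 3 stands: every value shown for this series sits at the same limit, so compound 3 cannot be placed above or below compound 1 or compound 2; no order among the three can be read. For the measured compounds named here, the single step between measured compounds that differ in one place, a step that the two limits leave unreadable from compound 2 to compound 3, is unreadable because both of its ends sit at the limit of > 100000 nM in this assay, at which 3 of the 3 values shown sit.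

Compound 4, `C=CC1=C(C(=O)NC(C)(C)C)C(c2ccc(Cl)c(Cl)c2)OC1`, differs from compound 3 by tert-butyl in place of isobutyl on an amide-type nitrogen. Going by the values given here, no measured step bears on an exchange of this kind on the amide-type nitrogen; the one recorded change in that region is the unreadable step just named, and the three values offer nothing beyond the limit itself. The expectation for compound 4 therefore rests on (the limit of > 100000 nM in this assay, at which 3 of the 3 values shown sit), where all values shown sit.

Compound 4 is expected to remain at or beyond that limit, with an estimate of 150000 nM (range 50000 nM to 500000 nM). The step this estimate means, a step that the limit leaves unreadable from compound 3 to compound 4, is expected to be none beyond the scatter.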

Compound 4, half-maximal inhibitory concentration: > 100000 nM
Compound 4: a limit, no number; the forecaster's own chance of this, stated with the estimate: 85%; the middle value lies beyond the limit too.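

No new step can be read from compound 2 to compound 4 or from compound 3 to compound 4 in this assay, because both ends of each sit at a limit and not at a number: the limit of > 100000 nM in this assay, at which 4 of the 4 values shown sit.

The compounds shown leave open whether any change to the shared core or its amide-type nitrogen gives a measurable value in this assay.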